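Amide aryl swap on the shared core, cytotoxicity notes

The compounds below may be only part of what the source reports. "The series", "measured", "known", "first", "only" and "open" are said of these compounds alone.

Compound 1 `Cc1ccc(F)cc1NC(=O)CN1CCN(c2nnc(Cc3ccccc3)c3ccccc23)CC1` carries a 5-fluoro-2-methylphenyl on the amide-type nitrogen of the shared core; in a functional assay on A549 cells (Homo sapiens) for cytotoxicity, read by MTT assay, with a stated time of 72 h (a higher number here means a weaker inhibitor, a lower number a stronger inhibitor), compound 1 gives "not active" (no number reported), so no single number stands for it. Compound 2 `O=C(CN1CCN(c2nnc(Cc3ccccc3)c3ccccc23)CC1)Nc1ccc(F)c(F)c1` keeps the same core and in this assay compound 2 gives 10100 nM. Compound 3 `O=C(CN1CCN(c2nnc(Cc3ccncc3)c3ccccc23)CC1)Nc1cccc(Br)c1` differs from the others in more than one place, and in this assay compound 3 gives 1530 nM. Compound 4 `O=C(CN1CCN(c2nnc(Cc3ccccc3)c3ccccc23)CC1)Nc1ccc(F)c(Cl)c1` has not yet been measured. Relative to compound 1 the change is 3-chloro-4-fluorophenyl in place of 5-fluoro-2-methylphenyl on an amide-type nitrogen. For the measured compounds named here, no single-change step between measured compounds is available, so the size of the move from compound 1 to compound 4 in this assay cannot be read from a measured pair; the expectation is that compound 4 registers a number where compound 1 did not, because compound 2 gives 10100 nM with a closely related aryl amide on the same core. Compound 4 is estimated at 6000 nM, with a range of 2000 nM to 20000 nM.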

Compound 4, half-maximal inhibitory concentration: "not active" (no number reported)
Compound 4: no number reported; no gap can be computed for the estimate.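

Compound 1 and compound 4 both stand without a number in this assay, so no new step can be read from them. No measurement at hand explains this result. The compounds shown leave open how far the amide aryl group alone shifts cytotoxicity on the shared core.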